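The source may report more compounds than this note shows. Statements on the series, on what has been measured and on what is new or still open speak of the compounds shown alone.

In a functional assay on MCF7 cells (Homo sapiens) for inhibition, read by MTT assay, with a stated time of 72 h (a higher number here means a weaker inhibitor, a lower number a stronger inhibitor), compound 1 (`C=C(Br)C(=O)Nc1cccc(/C=C/C(=O)Nc2ccccc2)c1`) gives 27300 nM and compound 2 (`C=C(Br)C(=O)Nc1cccc(/C=C/C(=O)Nc2ccc(F)cc2)c1`) gives 13600 nM, so these two values cannot be told apart. Compound 3 (`C=C(Br)C(=O)Nc1cccc(/C=C/C(=O)Nc2cccc(F)c2)c1`) differs from compound 2 by 3-fluorophenyl in place of 4-fluorophenyl on an amide-type nitrogen. Within the data shown here, only one measured step bears on this change, a 2.0-fold lower number from compound 1 to compound 2 (0.30 log units; within the scatter), where fluoro replaces hydrogen on an aromatic carbon. Among the measured compounds shown here, with so small a step as the only guide, no change beyond the scatter is expected in this assay, in either direction. The expected change is a 1.2-fold higher number from compound 2 to compound 3 (0.07 log units; within the scatter). Compound 3 is estimated at 16000 nM, with an expected range from 8000 nM to 32000 nM.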

Compound 3, half-maximal inhibitory concentration: 3300 nM
Beside the measured number, compound 3's estimate is 4.8-fold (0.69 log units) above it; the measured number lies below the stated range.
By their numbers in this assay, from the lowest: compound 3; then compounds 2 and 1 (each within the scatter of the next).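

The two fluorinated compounds have the same atoms joined differently, yet they give a 4.1-fold lower number from compound 2 to compound 3 (0.62 log units; beyond the scatter) in this assay, so where the fluoro sits on this ring matters here. Compared with the plain phenyl group, 3-fluorophenyl gives an 8.3-fold lower number from compound 1 to compound 3 (0.92 log units; beyond the scatter), a step beyond the scatter that 4-fluorophenyl did not show. No evidence here explains this difference between the two fluorinated groups. From the compounds shown here alone, whether chloro or methoxy in place of the fluoro of 3-fluorophenyl would give a similar number remains open.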